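The compounds below may be only part of what the source reports. "The series", "measured", "known", "first", "only" and "open" are said of these compounds alone.

Measured so far in an assay for inhibition of Tryptophan 2,3-dioxygenase (Homo sapiens), with stated times of 10 min and 60 min, tested at 100 uM; on this read-out lower numbers stand for a weaker effect and higher numbers for a stronger effect at the one concentration tested:
- compound 1 `O=[N+]([O-])c1cc(OCc2ccccc2)ccc1CNc1cc(C(F)(F)F)cc2[nH]ncc12` gives 55%
- compound 2 `O=C(O)CNc1cccc(CNc2cc(C(F)(F)F)cc3[nH]ncc23)c1` gives 65%
- compound 3 `O=[N+]([O-])c1ccc(CNc2cc(Br)cc3[nH]ncc23)cc1` gives 93%

Compound 2 sits within the usual scatter of compound 1 in this assay and clearly under compound 3, whose number stands beyond the scatter above it. Among the compounds with values here, no step between two measured compounds that differ in one place is available, so nothing here tells how much a single change on the benzyl ring moves the read-out.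

Compound 4 `FC(F)(F)c1cc(NCc2cccc(Br)c2)c2cn[nH]c2c1` is the next case, with the change (bromo in place of (carboxymethyl)amino on an aromatic carbon). Within the data shown here, with no matching step to lean on, no change beyond the scatter is expected, with at most a small rise. Compound 4 is therefore expected to give about 70% in this assay, within 45% to 90%, an estimated step of a number 5 percentage points higher from compound 2 to compound 4 (within the scatter).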

Compound 4, a percentage reported as inhibition, at one concentration (the size of the read-out at that concentration, not a potency): 84%
Compound 4: the middle estimate sits 14 percentage points below what was measured; the measured number falls inside the stated range.
By their numbers in this assay, from the lowest: compounds 1 and 2 (each within the scatter of the next); then compounds 4 and 3 (each within the scatter of the next).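

In this assay, within the data shown here, bromo in place of (carboxymethyl)amino on an aromatic carbon, meta to a large group, gives a number 19 percentage points higher from compound 2 to compound 4 (beyond the scatter), the first single-place step. At this position, the (carboxymethyl)amino group, with its hydrogen-bond donors and acceptors, is therefore not required for a strong read-out, as bromo has neither. No data here give a reason for this step.

From the compounds shown here alone, whether an amine, a carboxylic acid or a longer chain on this carbon would track bromo or (carboxymethyl)amino remains open. Also open, going by these compounds, is whether chloro or methoxy would match bromo here.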